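Taking ethoxycarbonyl away from compound 2

The compounds below may be only part of what the source reports. "The series", "measured", "known", "first", "only" and "open" are said of these compounds alone.

Of the compounds shown here, two have so far been measured in a physicochemical assay for lipophilicity, measured as octanol-water partition, at pH 7.4; a lower number here means a more polar compound, a higher number a more lipophilic compound. Compound 1 `CC(=O)N[C@H](C(=O)N1C[C@H](O)C[C@H]1C(=O)N[C@@H](CCC(C)(C)C)c1ccc(-c2scnc2C)cc1)C(C)(C)C` gives 3.21, and compound 2 `CCOC(=O)CC[C@H](NC(=O)[C@@H]1C[C@@H](O)CN1C(=O)[C@@H](NC(C)=O)C(C)(C)C)c1ccc(-c2scnc2C)cc1` gives 1.59, the lower of the two numbers and clearly beyond the scatter. Compound 3 `CCCC[C@H](NC(=O)[C@@H]1C[C@@H](O)CN1C(=O)[C@@H](NC(C)=O)C(C)(C)C)c1ccc(-c2scnc2C)cc1` has not yet been measured. It carries ethyl in place of ethoxycarbonyl on a saturated chain carbon, three bonds along the chain from an amide-type nitrogen and an aromatic carbon. For the measured compounds named here, the one measured step that bears on this change is a number 1.62 log units lower from compound 1 to compound 2 (beyond the scatter), which came with ethoxycarbonyl in place of tert-butyl at that same place. Now that ethoxycarbonyl leaves, a rise is expected in this assay, but ethyl is a smaller group than tert-butyl, which suggests a smaller rise than that earlier fall. The expected step is a number 1.01 log units higher from compound 2 to compound 3 (beyond the scatter). For compound 3 the estimate is 2.6, with an expected range of 2.2 to 3.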

Compound 3, distribution coefficient: 2.75
Compound 3: middle estimate off by 0.15 log units, on the low side, within the range that was stated.
By their numbers in this assay, from the lowest: compound 2; then compound 3; then compound 1.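

Ethyl in place of ethoxycarbonyl brings a number 1.16 log units higher from compound 2 to compound 3 (beyond the scatter), which shows that this saturated chain carbon still strongly affects the reading in this assay when the ester group leaves. Ethyl and tert-butyl, both groups without a hydrogen-bond acceptor, do not give the same reading either, with a number 0.46 log units lower from compound 1 to compound 3 (beyond the scatter), so the number here depends on more than the presence or absence of the ester. Nothing measured here explains the size of either step.

The compounds shown leave open how a longer chain, an amine or a carboxylic acid at this same place would read in this assay. They also leave open whether these exchanges would give steps of similar size on another core, as all three compounds share one.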